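Trading One Fluoro for Hydrogen on Compound 2

The source may hold more compounds than are shown below. What is called first, only, known or untested is meant among the compounds shown, and "the series" means these compounds.

In an ADME assay on a cell-free system (plasma, Mus musculus) for protein binding (on this read-out higher numbers stand for a larger free fraction and lower numbers for a smaller free fraction), compound 1 (`CC(C)Cc1ccc(-c2cn(C)c3cc(C(=O)NS(C)(=O)=O)ccc23)cc1`) gives 0.003 and compound 2 (`Cn1cc(-c2ccc(C(F)(F)F)cc2)c2cc(F)c(C(=O)NS(C)(=O)=O)cc21`) gives 0.005, so compound 2 stands within the scatter of compound 1. Compound 3 (`Cn1cc(-c2ccc(C(F)(F)F)cc2)c2ccc(C(=O)NS(C)(=O)=O)cc21`) carries hydrogen in place of fluoro on an aromatic carbon of compound 2 (hydrogen in place of fluoro on an aromatic carbon). Among the measured compounds shown here, no measured pair shows this change alone. Compound 1 (0.003) also has hydrogen on that carbon, so no step beyond the scatter is expected in this assay. The expected step is small (a 1.3-fold lower number from compound 2 to compound 3 (0.10 log units; within the scatter)). For compound 3 the estimate is 0.004, within an expected range of 0.002 to 0.008.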

Compound 3, unbound fraction: < 0.001
Compound 3 was reported as a limit (the forecaster's own chance of this, stated with the estimate: 3%); middle value at least 4.0-fold (0.60 log units) from the limit.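

Here a single atom on the aromatic carbon ortho to the (methylsulfonyl)carbamoyl group counts in this assay: hydrogen in place of fluoro gives an at least 5.0-fold lower number from compound 2 to compound 3 (0.69 log units; beyond the scatter). The group on the far aromatic ring counts too, since trifluoromethyl in place of isobutyl gives an at least 3.0-fold lower number from compound 1 to compound 3 (0.47 log units; beyond the scatter). Compound 3 is reported only as a limit, so both steps have a floor and no measured size: the limit of < 0.001 in this assay, at which 1 of the 3 values shown sits.

The compounds shown leave open whether fluoro would have the same weight with isobutyl in the molecule. They also leave open where chloro, methoxy or an amine on that carbon would fall.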